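Swapping the outer ring on the alkyne linker

The source may report more compounds than this note shows. Statements on the series, on what has been measured and on what is new or still open speak of the compounds shown alone.

Compound 3 `C=Cc1nccc(C#Cc2ccc3ncn(-c4ccnc(N)n4)c3c2)n1`: 39800 nM
Compound 1 `C#Cc1cccc(C#Cc2ccc3ncn(-c4ccnc(N)n4)c3c2)n1`: 3160 nM
Compound 2 `C=Cc1ccnc(C#Cc2ccc3ncn(-c4ccnc(N)n4)c3c2)n1`: 1580 nM

In an assay on Sf9 cells for inhibition of mitogen-activated protein kinase kinase kinase 14 variant S549D (Homo sapiens), with a stated time of 30 min, in the presence of a further agent that is not named here (a lower number here means a stronger inhibitor, a higher number a weaker inhibitor), compound 3 gives the highest number of the three, beyond the scatter from both others: a 13-fold higher number from compound 1 to compound 3 (1.10 log units; beyond the scatter) and a 25-fold higher number from compound 2 to compound 3 (1.40 log units; beyond the scatter). Compound 4 `C#Cc1ncc(C#Cc2ccc3ncn(-c4ccnc(N)n4)c3c2)cn1` differs from compound 3 in one place: a group of 8 heavy atoms (6 carbon, 2 nitrogen; one six-membered aromatic ring with 2 hetero atoms) in place of a group of 8 heavy atoms (6 carbon, 2 nitrogen; one six-membered aromatic ring with 2 hetero atoms), on a triple-bonded carbon; the ring that leaves carries a double bond outside aromatic rings, the one that enters a triple bond outside aromatic rings. Every measured step is a swap of this outer ring, and the sizes range from a 2.0-fold lower number from compound 1 to compound 2 (0.30 log units; within the scatter) to the large moves above, so another swap may move the number a lot in either direction. Since compound 3 sits at the weak end, the expected move in this assay is a moderately lower number, a 6.6-fold lower number from compound 3 to compound 4 (0.82 log units; beyond the scatter). Compound 4 is estimated at 6000 nM, between 1200 nM and 30000 nM.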

Compound 4, half-maximal inhibitory concentration: 79400 nM
Compound 4: the middle estimate sits 13-fold (1.12 log units) below what was measured; the whole stated range lies below it.
By their numbers in this assay, from the lowest: compounds 2 and 1 (each within the scatter of the next); then compounds 3 and 4 (each within the scatter of the next).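

In this assay the change from a double bond to a triple bond outside the aromatic ring gives only a 2.0-fold higher number from compound 3 to compound 4 (0.30 log units; within the scatter) and so leaves this ring at the weak end. A triple bond alone does not set the number, since a 25-fold higher number from compound 1 to compound 4 (1.40 log units; beyond the scatter) links two rings that both carry one. Among the compounds shown here, the widest step so far, a 50-fold higher number from compound 2 to compound 4 (1.70 log units; beyond the scatter) in size, also falls on a swap of this ring.

As far as these compounds go, whether an amine or a carboxylic acid on this ring would give a lower number stays open. Nothing available explains why these rings differ.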